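This account rests on a few compounds, and the source may have more. Where it says the series, first, only, none or still open, it means among the compounds named here.

Going by the values given here, in a functional assay on HCT-116 cells (Homo sapiens) for antiproliferative activity, read by MTT assay, with a stated time of 72 h (a lower number here means a stronger inhibitor, a higher number a weaker inhibitor), compound 1 `Cc1ccc(N2CCN(C(=S)SCc3ccc4nc(N)nc(N)c4c3)CC2)c(C)c1` gives 4070 nM and compound 2 `Nc1nc(N)c2cc(CSC(=S)N3CCN(c4ccc(Cl)c(Cl)c4)CC3)ccc2n1` gives 6680 nM, so compound 2 stands level with its only measured neighbour. Compound 3 `CC(=O)c1ccc(N2CCN(C(=S)SCc3ccc4nc(N)nc(N)c4c3)CC2)cc1` differs from compound 2 on an amine nitrogen in a ring: 4-acetylphenyl in place of 3,4-dichlorophenyl on an amine nitrogen in a ring. Among the compounds with values here, the one measured step at this place, a 1.6-fold higher number from compound 1 to compound 2 (0.22 log units; within the scatter), exchanged one aryl group for another, so no change beyond the scatter is expected, although no compound carrying 4-acetylphenyl has a measured value yet. For compound 3 the estimated value is 5000 nM, with an expected range of 1800 nM to 14000 nM. The expected step is a 1.3-fold lower number from compound 2 to compound 3 (0.13 log units; within the scatter).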

Compound 3, half-maximal inhibitory concentration: 8260 nM
The estimate for compound 3 lay 1.7-fold (0.22 log units) below the measured number; measured number inside the range.
By their numbers in this assay, from the lowest: compounds 1, 2 and 3 (each within the scatter of the next, the first and the last beyond it).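

Swapping 3,4-dichlorophenyl for 4-acetylphenyl on the amine nitrogen in this assay brings in a hydrogen-bond acceptor, yet gives a 1.2-fold higher number from compound 2 to compound 3 (0.09 log units; within the scatter). Going by these compounds alone, replacing 2,4-dimethylphenyl with 4-acetylphenyl gives a 2.0-fold higher number from compound 1 to compound 3 (0.31 log units; beyond the scatter), the only step at this position that passes the scatter, and it is modest. Nothing available explains these differences. The compounds shown leave open what a basic amine or a carboxylic acid on the phenyl ring would do, and whether a saturated cyclohexyl ring or a plain alkyl chain could replace the aryl group on that nitrogen.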